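This account rests on a few compounds, and the source may have more. Where it says the series, first, only, none or still open, it means among the compounds named here.

Compounds measured in a functional assay on K562 cells (Homo sapiens) for inhibition, read by MTT assay, with a stated time of 48 h (on this read-out lower numbers stand for stronger inhibition and higher numbers for weaker inhibition), so far:
- compound 1 `Nc1n[nH]c2cc(-c3cn([C@@H]4CN[C@H](C(=O)Nc5ccc(Cl)cc5Cl)C4)nn3)ccc12` gives 28400 nM
- compound 2 `CC(=O)Nc1nc2ccc(-c3cn([C@@H]4CN[C@H](C(=O)Nc5ccc(Cl)c(C(F)(F)F)c5)C4)nn3)nc2s1` gives 10000 nM
- compound 3 `Nc1nc2ccc(-c3cn([C@@H]4CN[C@H](C(=O)Nc5ccc(Cl)cc5Cl)C4)nn3)nc2s1` gives 24500 nM

Compound 3 lies within the scatter of compound 1 and above compound 2, so it belongs to the upper end of these three numbers. Compound 4 `CC(=O)Nc1nc2ccc(-c3cn([C@@H]4CN[C@H](C(=O)Nc5ccc(Cl)cc5Cl)C4)nn3)nc2s1` is compound 3 with one change, acetyl in place of hydrogen on a nitrogen on an aromatic ring which turns amino to acetamido. Within the data shown here, the only measured step, a 1.2-fold lower number from compound 1 to compound 3 (0.06 log units; within the scatter) changes the core and not this nitrogen, so it bears on the change only weakly. Compound 2 with 10000 nM carries the acetamido group but differs elsewhere as well, so it offers only a faint hint toward a lower number. The expected step, a 1.4-fold lower number from compound 3 to compound 4 (0.13 log units; within the scatter) stays within the scatter in this assay and no larger move is foreseen. For compound 4 the estimated value is 18000 nM with an expected range from 8000 nM to 40000 nM as its spread.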

Compound 4, half-maximal inhibitory concentration: 9670 nM
Beside the measured number, compound 4's estimate is 1.9-fold (0.27 log units) above it, and the stated range covers the measured number.
By their numbers in this assay, from the lowest: compounds 4 and 2 (each within the scatter of the next); then compounds 3 and 1 (each within the scatter of the next).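

In this assay the change from amino to acetamido on this nitrogen, now seen on its own, gives a 2.5-fold lower number from compound 3 to compound 4 (0.40 log units; beyond the scatter) as a modest move beyond the scatter. With the acetamido group kept, a 1.0-fold lower number from compound 2 to compound 4 (0.01 log units; within the scatter) does not separate 2,4-dichlorophenyl from 4-chloro-3-(trifluoromethyl)phenyl on the amide-type nitrogen. No available evidence accounts for the effect of the acetyl group.

From the compounds shown here alone, whether a propionyl or methylsulfonyl group on this nitrogen would move the number further stays open. So does whether acetyl has the same effect on the core of compound 1.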